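The compounds below may be only part of what the source reports. "The series", "measured", "known", "first", "only" and "open" are said of these compounds alone.

Compound 1 `CNS(=O)(=O)c1ccc(C)c(C#Cc2cc(Cl)ccc2OCC(=O)O)c1` is the reference point of the pair measured so far. In an assay on CHO cells for displacement of a labelled ligand from prostaglandin D2 receptor 2 (Homo sapiens), read by scintillation counting (a lower number here means a stronger inhibitor, a higher number a weaker inhibitor), compound 1 gives 10 nM, the lowest of the two numbers in hand; compound 2 `O=C(O)COc1ccc(Cl)cc1C#Cc1ccc(F)cc1F` gives 101 nM in this assay, a higher number that lies beyond the scatter. Going by the values given here, no pair of measured compounds differing in a single place is available, so no measured step can guide the next change. Compound 3 `Cc1ccc(S(=O)(=O)N(C)C(C)C)cc1C#Cc1cc(Cl)ccc1OCC(=O)O` differs from compound 1 in one place: isopropyl in place of hydrogen on a sulfonamide nitrogen. Nothing measured bears on a change at the sulfonamide nitrogen, and the rest of the core of compound 1 is kept. The step of a 2.0-fold higher number from compound 1 to compound 3 (0.30 log units; within the scatter) is expected to be small, a modest move toward a higher number, at or near the edge of the scatter. Compound 3 is therefore estimated at 20 nM in this assay, with a range from 5 nM to 70 nM.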

Compound 3, inhibition constant: 3.8 nM
Compound 3: the middle estimate sits 5.3-fold (0.72 log units) above what was measured, outside the stated range (below it).
By their numbers in this assay, from the lowest: compound 3; then compound 1; then compound 2.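

In this assay, going by these compounds alone, the change from methylsulfamoyl to isopropyl(methyl)sulfamoyl gives a 2.6-fold lower number from compound 1 to compound 3 (0.42 log units; beyond the scatter), the first measured single-place step. In this pair, the hydrogen on the sulfonamide nitrogen is not needed to reach a low number, and that nitrogen tolerates isopropyl on the core of compound 1, with the number moving down rather than up. No measurement on hand explains the size or direction of this step.

Open, on these data alone, is whether the gain is specific to isopropyl or would also come with ethyl, cyclopropyl, tert-butyl or a longer chain on the same nitrogen, and whether a chain ending in a hydroxyl or an amine would be tolerated there. Also open, as far as these compounds go, is what the methyl on that nitrogen contributes, which a nitrogen bearing isopropyl and hydrogen would address.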